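The compounds below may be only part of what the source reports. "The series", "measured", "known", "first", "only" and "open" are said of these compounds alone.

Measured compounds:
compound 1, `CCCCCCCCCCCCNC(=O)[C@@H](NC(=O)c1ccccc1)[C@@H](C)O`; in a functional assay on MCF7 cells (Homo sapiens) for cytotoxicity, read by MTT assay, with a stated time of 48 h (a lower number here means a stronger inhibitor, a higher number a weaker inhibitor), compound 1 gives 36600 nM.
compound 2, `CCCCCCCCCCCCNC(=O)[C@@H](NC(=O)c1cccs1)[C@@H](C)O`; in this assay compound 2 gives 30400 nM.
compound 3, `CCCCCCCCCCCCNC(=O)[C@@H](NS(=O)(=O)c1ccc(C)cc1)[C@@H](C)O`; in this assay compound 3 gives 31100 nM.

Compound 3 stands second highest of the three numbers. Its nearest neighbour is compound 2, a 1.0-fold higher number from compound 2 to compound 3 (0.01 log units; within the scatter); its furthest is compound 1, a 1.2-fold lower number from compound 1 to compound 3 (0.07 log units; within the scatter); both gaps sit within the scatter, so the three compounds are not separated.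

Compound 4, `CCCCCCCCCCCCNC(=O)[C@@H](NS(=O)(=O)c1cccs1)[C@@H](C)O`, is not yet measured. The change is thiophen-2-yl in place of 4-methylphenyl on a sulfonyl sulfur. The step that bears on it most closely is the same swap of aryl group made on a carbonyl carbon in the amide pair, a 1.2-fold lower number from compound 1 to compound 2 (0.08 log units; within the scatter), which stayed within the scatter. Within the data shown here, the 4-methylphenyl of compound 3 carries a methyl that thiophen-2-yl lacks, and no measured step isolates that methyl on a sulfonyl sulfur. Among the measured compounds shown here, with no measured step reaching beyond the scatter, no step beyond the scatter is expected in this assay.

Compound 4 is therefore expected at 31000 nM, with a range from 15000 nM to 65000 nM. The expected step is a 1.0-fold lower number from compound 3 to compound 4 (0.00 log units; within the scatter).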

Compound 4, half-maximal inhibitory concentration: 19100 nM
Compound 4: the middle estimate sits 1.6-fold (0.21 log units) above what was measured, and the stated range covers the measured number.
By their numbers in this assay, from the lowest: compounds 4, 2, 3 and 1 (each within the scatter of the next).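

On a sulfonyl sulfur, thiophen-2-yl in place of 4-methylphenyl gives a 1.6-fold lower number from compound 3 to compound 4 (0.21 log units; within the scatter), so this aryl swap stays within the scatter on the sulfonyl sulfur, as it did on a carbonyl carbon. Among these compounds, with thiophen-2-yl held constant, the sulfonyl in place of the carbonyl gives a 1.6-fold lower number from compound 2 to compound 4 (0.20 log units; within the scatter), and the change from the benzoyl amide gives a 1.9-fold lower number from compound 1 to compound 4 (0.28 log units; within the scatter), the largest step so far, yet still within the scatter, which leaves all four compounds unseparated in this assay. No evidence on hand bears on these small steps.

As far as these compounds go, whether a carboxylic acid or an amine on the aryl ring would move the number beyond the scatter remains open. So does the effect of a shorter or longer chain on the amide nitrogen, which is the same in all four compounds.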